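Lengthening the Chain on the Amide Nitrogen

A few compounds are considered here, and "the series" means these few. Any claim that something is new, unique, unknown or untested is made for them only; others in the source may bear on it.

Compound 3 `Cc1ccc(OCC(=O)N(C)Cc2cccs2)cc1` carries only a methyl on its amide nitrogen. Going by the values given here, in an assay on HEK293 cells for agonist activity at transient receptor potential cation channel subfamily M member 8 (Homo sapiens), read by fluorescence and calcium flux, with a stated time of 15 min (a higher number here means that more compound is needed for the effect, a lower number that less compound is needed), compound 3 gives 400 nM, the second highest of the three numbers so far. Compound 2 `Cc1ccc(OCC(=O)N(Cc2cccs2)c2ccccn2)cc1` gives 200 nM in this assay, and the step of a 2.0-fold higher number from compound 2 to compound 3 (0.30 log units; within the scatter) lies within the scatter, so the two cannot be told apart. Compound 1 `Cc1ccc(OCC(=O)N(Cc2cccs2)CC(C)C)cc1` gives 900 nM; here the step of a 2.3-fold lower number from compound 1 to compound 3 (0.35 log units; beyond the scatter) is beyond the scatter, as is a 4.5-fold lower number from compound 1 to compound 2 (0.65 log units; beyond the scatter).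

Compound 4 `CCCN(Cc1cccs1)C(=O)COc1ccc(C)cc1` differs from compound 3 by ethyl in place of hydrogen on a saturated chain carbon bound to an amide-type nitrogen. This partly reverses the change that led from compound 1 to compound 3, where an isopropyl was removed from that same carbon, and the step of a 2.3-fold lower number from compound 1 to compound 3 (0.35 log units; beyond the scatter) was modest. Compound 4 sits between the two in chain length, so a rise in the number smaller than that step is expected.

Compound 4 is expected to give about 600 nM in this assay, with a range from 250 nM to 1500 nM. The step of a 1.5-fold higher number from compound 3 to compound 4 (0.18 log units; within the scatter) is expected to be modest, possibly within the scatter.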

Compound 4, half-maximal effective concentration: 40 nM
Compound 4: middle estimate off by 15-fold (1.18 log units), on the high side; measured number below the stated range.
By their numbers in this assay, from the lowest: compound 4; then compounds 2 and 3 (each within the scatter of the next); then compound 1.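

In this assay, going by these compounds alone, this position proves far more sensitive than the earlier compounds suggested: extending the methyl on the amide nitrogen to propyl gives a 10-fold lower number from compound 3 to compound 4 (1.00 log units; beyond the scatter) and is the largest gain so far from a small change of chain. The propyl chain also compares well with the other two groups, with a 5.0-fold lower number from compound 2 to compound 4 (0.70 log units; beyond the scatter) against the pyridin-2-yl and a 23-fold lower number from compound 1 to compound 4 (1.35 log units; beyond the scatter) against the isobutyl, so the number does not simply fall as the group grows, and compound 1, with the largest chain, has the highest number. Nothing available here explains why the propyl chain gives so low a number. As far as these compounds go, whether a longer straight chain such as butyl or pentyl lowers the number further remains open. So does the result for an ethyl on the same nitrogen.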